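The source may report more compounds than this note shows. Statements on the series, on what has been measured and on what is new or still open speak of the compounds shown alone.

Compound 1 `CC1(C)CCCC2=C1C[C@@H](C(=O)O)[C@H](c1ccccc1)C2` carries a hydroxy on a carbonyl carbon. In an assay on isolated protein for inhibition of Apoptosis regulator Bcl-2 (Homo sapiens), read by fluorescence polarization, with stated times of 5 min and 10 min (a lower number here means a stronger inhibitor, a higher number a weaker inhibitor), compound 1 gives > 23000 nM, which is a limit of the assay rather than a number. Compound 2 `CON(C)C(=O)[C@@H]1CC2=C(CCCC2(C)C)C[C@H]1c1ccccc1` puts a methoxy(methyl)amino group in place of that hydroxy on the carbonyl carbon. In this assay compound 2 gives > 23000 nM, again a limit. The change from compound 1 to compound 2 therefore gives a step that the two limits leave unreadable from compound 1 to compound 2. Compound 3 `CC(C)=CCCC1=CC[C@H](C(N)=O)[C@@H](c2ccccc2)C1` is a third member of the set. In this assay compound 3 gives > 23000 nM, also a limit. Where compound 1 stands can only be said as a limit: it sits at the limit of > 23000 nM in this assay, at which 3 of the 3 values shown sit.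

Compound 4 `CC1(C)CCCC2=C1C[C@H](C(=O)O)[C@@H](c1ccccc1)C2` is the mirror image of compound 1: the two compounds have the same atoms and bonds and differ only in configuration as drawn: 2 of 2 stereo elements differ (all stereocentres are inverted: mirror images); a stereocentre at a saturated ring carbon is drawn R in compound 1 and S in compound 4; a stereocentre at a saturated ring carbon is drawn R in compound 1 and S in compound 4. Among the measured compounds shown here, no measured step covers an inversion of configuration, and the one step available, from compound 1 to compound 2, was left unreadable by its two limits. With every value shown at the limit, nothing suggests that the mirror image of compound 1 would drop into the measurable range. The expected step is a step that the limit leaves unreadable from compound 1 to compound 4, which here means no readable change. Compound 4 is estimated at 30000 nM, within 15000 nM to 100000 nM, with the most likely outcome being another limit.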

Compound 4, inhibition constant: > 23000 nM
Compound 4 ended at the assay's limit; the forecaster's own chance of this, stated with the estimate: 85%; the middle value is on the limit's open side.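

No step can be read from compound 1 to compound 4, as the result for compound 4 in this assay is again a limit and not a number: the limit of > 23000 nM in this assay, at which 4 of the 4 values shown sit. The compounds shown leave open whether the configuration of compound 1 or compound 4 matters at all in this assay, as none of them yet gives a measurable number.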